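The source may hold more compounds than are shown below. What is called first, only, known or untested is meant among the compounds shown, and "the series" means these compounds.

Measured so far:
compound 1, `COc1cc(-c2cc(/C=C/C(=O)c3ccc(N)cc3)[nH]n2)cc(OC)c1OC`, 8930 nM
compound 2, `COc1ccc(-c2cc(/C=C/C(=O)c3ccc(OC)c(OC)c3)[nH]n2)cc1`, 5740 nM

The two compounds were tested in a functional assay on SK-MEL-28 cells (Homo sapiens) for inhibition, read by sulforhodamine B assay, with a stated time of 48 h; a lower number here means that less compound is tolerated, a higher number that more compound is tolerated. Compound 1 gives 8930 nM, the highest of the two numbers; its nearest neighbour is compound 2 with 5740 nM, and the gap between them lies within the scatter, so the two cannot be ordered.

The next compound is compound 3, `COc1cc(-c2cc(/C=C/C(=O)c3ccc(Cl)c(Cl)c3)[nH]n2)cc(OC)c1OC`. It differs from compound 1 in one place: 3,4-dichlorophenyl in place of 4-aminophenyl on a carbonyl carbon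

For the measured compounds named here, no step between measured compounds is available to calibrate this change. The account therefore expects a modest shift for compound 3, toward a somewhat lower number than compound 1, but one that may not rise above the scatter. Compound 3 is estimated at 6000 nM, with a range from 2000 nM to 18000 nM, which corresponds to an expected step of a 1.5-fold lower number from compound 1 to compound 3 (0.17 log units; within the scatter) in this assay.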

Compound 3, concentration lethal to 50% of the cells: > 100000 nM
Compound 3: a limit, no number; the forecaster's own chance of this, stated with the estimate: 5%; at least 16-fold (1.22 log units) between middle value and limit.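

Compound 3 gives > 100000 nM in this assay, which is a limit of the assay and not a number. Putting 3,4-dichlorophenyl in place of 4-aminophenyl on the carbonyl carbon gives an at least 11-fold higher number from compound 1 to compound 3 (1.04 log units; beyond the scatter), the first step available at this position, and it shows that the group held there can move this read-out beyond the scatter, toward more compound being tolerated. How far the step truly reaches stays unknown, as the result marks only a limit: the limit of > 100000 nM in this assay, at which 1 of the 3 values shown sits.

As far as these compounds go, what remains open is which part of the change carries the step, the loss of the amine or the arrival of the two chlorine atoms, since both occur together here. A 4-chlorophenyl or an unsubstituted phenyl on the same carbonyl carbon would bear on that question.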